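The source may report more compounds than this note shows. Statements on the series, on what has been measured and on what is new or still open speak of the compounds shown alone.

Measured compounds and their values in a functional assay on the whole organism (liver, strain NMRI) for inhibition, with Mus musculus as the target, with a stated time of 3 h, at a dose of 3 mg/kg by the oral route; on this read-out lower numbers stand for less inhibition and higher numbers for more inhibition at the one dose given (going by the name of the read-out):

Compound 1, `O=[N+]([O-])c1cc(-c2nc(-c3ccccc3)no2)cc(O)c1O`: 20.6%
Compound 2, `O=[N+]([O-])c1cc(-c2nc(-c3ccc(F)cc3)no2)cc(O)c1O`: 12.7%
Compound 3, `O=[N+]([O-])c1cc(-c2nc(-c3ccc(Br)cc3)no2)cc(O)c1O`: 12.7%

Compound 3 stands level with compound 2 at the digits given, and the two share the lowest number of the three. Its nearest neighbour is compound 2, no change at the digits printed from compound 2 to compound 3 (within the scatter), and its furthest is compound 1, which sits higher by the amount shown in a number 7.9 percentage points lower from compound 1 to compound 3 (within the scatter).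

Compound 4, `NC(=O)c1ccc(-c2noc(-c3cc(O)c(O)c([N+](=O)[O-])c3)n2)cc1`, has not yet been measured. It differs from compound 3 in one place: carbamoyl in place of bromo on an aromatic carbon. The group sits on an aromatic carbon of a six-membered aromatic ring of carbon only.

Among the measured compounds shown here, the steps that bear on this change are those at the same position: a number 7.9 percentage points lower from compound 1 to compound 2 (within the scatter), a number 7.9 percentage points lower from compound 1 to compound 3 (within the scatter) and no change at the digits printed from compound 2 to compound 3 (within the scatter). Each of them lies within the scatter, so swapping hydrogen, fluoro and bromo at this carbon has moved the read-out by no more than the usual spread. For the measured compounds named here, a carbamoyl group is a different kind of substituent from a halogen, and none of the measured compounds tells how such a group behaves here, but on the evidence of these three steps the expected step from compound 3 to compound 4 is a number 2.3 percentage points higher from compound 3 to compound 4 (within the scatter), that is, no change beyond the scatter. Compound 4 is therefore estimated to give 15%, within a range from 0% to 35%.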

Compound 4, a percentage reported as inhibition, in the whole organism at one dose (the size of the read-out at that dose, not a potency): 79.2%
Compound 4: middle estimate off by 64.2 percentage points, on the low side; the measured number lies above the stated range.
By their numbers in this assay, from the lowest: compounds 2, 3 and 1 (each within the scatter of the next); then compound 4.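

In this assay, the carbamoyl group gives a number 66.5 percentage points higher from compound 3 to compound 4 (beyond the scatter), and the comparisons with the other two compounds agree: a number 66.5 percentage points higher from compound 2 to compound 4 (beyond the scatter) and a number 58.6 percentage points higher from compound 1 to compound 4 (beyond the scatter). The earlier steps shown here among hydrogen, fluoro and bromo all stayed within the scatter and made this aromatic carbon, para to a large group, look indifferent to what it carries, but these steps show that the read-out can respond strongly to the group placed there, at least when a halogen or hydrogen gives way to carbamoyl. Nothing supplied here explains why this one replacement has so large an effect.

The compounds shown do not settle whether the rise needs the whole carbamoyl group or would also appear with a carboxylic acid, a nitrile, an amine or an N-methyl amide on the same carbon. On these data alone, as each compound is described by a single percentage at one dose and one time, how the carbamoyl compound would behave at other doses or times also remains open.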